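This account rests on a few compounds, and the source may have more. Where it says the series, first, only, none or still open, it means among the compounds named here.

In a functional assay on CHO cells for agonist activity at Free fatty acid receptor 2 (Homo sapiens), read by cAMP accumulation (on this read-out lower numbers stand for stronger inhibition and higher numbers for weaker inhibition), compound 1 `CC(C)C(C(=O)Nc1nnn[nH]1)c1ccc(Cl)cc1` gives 100000 nM. Compound 2 `CC(C)[C@H](C(=O)Nc1ncc(C(F)(F)F)s1)c1ccc(Cl)cc1` gives 1500 nM and compound 3 `CC(C)(C)[C@H](C(=O)Nc1ncc(C(F)(F)F)s1)c1ccc(Cl)cc1` gives 1500 nM; the step of no change at the digits printed from compound 2 to compound 3 (within the scatter) leaves the two level, and together they give the lowest numbers of the three, with compound 1 clearly above them. Compound 4 `CC(C)(C)[C@H](C(=O)Nc1ncc(C(O)(C(F)(F)F)C(F)(F)F)s1)c1ccc(Cl)cc1` carries 2,2,2-trifluoro-1-hydroxy-1-(trifluoromethyl)ethyl in place of trifluoromethyl on an aromatic carbon. Among the compounds with values here, the only measured step, no change at the digits printed from compound 2 to compound 3 (within the scatter), alters a saturated chain carbon and not the group on the five-membered ring; no measured pair changes that trifluoromethyl, so the series offers no direct guide for this change. On that basis no step beyond the scatter is expected, and the estimated no change at the digits printed from compound 3 to compound 4 (within the scatter) is kept small. Compound 4 is expected to give 1500 nM, with a range from 400 nM to 6000 nM.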

Compound 4, half-maximal inhibitory concentration: 1200 nM
The estimate for compound 4 lay 1.3-fold (0.10 log units) above the measured number; measured number inside the range.
By their numbers in this assay, from the lowest: compounds 4, 2 and 3 (each within the scatter of the next); then compound 1.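

In this assay, 2,2,2-trifluoro-1-hydroxy-1-(trifluoromethyl)ethyl in place of trifluoromethyl gives a 1.3-fold lower number from compound 3 to compound 4 (0.10 log units; within the scatter) on the aromatic carbon next to the ring sulfur. This position therefore takes the larger group, with its added hydrogen-bond donor and acceptor, without a step beyond the scatter. No accompanying measurement gives a reason for this result.

The compounds shown leave open whether a carboxylic acid, an amine or a nitrile at this position would behave alike. They also leave open whether a methyl ether of the hydroxyl would hold the number.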